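This account rests on a few compounds, and the source may have more. Where it says the series, first, only, none or still open, it means among the compounds named here.

Measured compounds:
compound 1 `Cc1ccc([C@@H]2CN(C)[C@]3(C(=O)Nc4ccccc43)[C@]23Cc2ccccc2C3=O)cc1`: 56.4%
compound 2 `CN1C(=O)[C@@]2(c3ccccc31)N(C)C[C@@H](c1ccc(Cl)cc1)[C@@]21Cc2ccccc2C1=O`: 47.2%

In a functional assay on the whole organism (strain Wister albino) for inhibition, with Rattus norvegicus as the target, read by paw edema, with a stated time of 1 h, at a dose of 50 mg/kg by the intraperitoneal route (on this read-out higher numbers stand for more inhibition at the one dose given (going by the name of the read-out) and lower numbers for less inhibition), compound 1 gives 56.4%. In this assay compound 2 gives 47.2%, the lower of the two numbers, but the gap to compound 1 lies within the usual scatter, so the two values cannot be told apart. Compound 3 `Cc1ccc([C@@H]2CN(C)[C@]3(C(=O)N(C)c4ccccc43)[C@]23Cc2ccccc2C3=O)cc1` is the next one to be tested in this assay. It differs from compound 2 by methyl in place of chloro on an aromatic carbon. For the measured compounds named here, no pair of measured compounds differing in just this one place exists, so the size of this step has no direct precedent. Given that compound 1 carries the same methyl and shows 56.4%, the step from compound 2 is expected to be small, in this assay amounting to a number 4.8 percentage points higher from compound 2 to compound 3 (within the scatter), not beyond the scatter. Compound 3 is therefore estimated to give 52%, within a range of 38% to 66%.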

Compound 3, a percentage reported as inhibition, in the whole organism at one dose (the size of the read-out at that dose, not a potency): 46.9%
Compound 3: middle estimate off by 5.1 percentage points, on the high side; measured number inside the range.
By their numbers in this assay, from the lowest: compounds 3, 2 and 1 (each within the scatter of the next).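

For the compounds shown here, with compound 3 in hand, this assay gives the first direct reading of the change from 4-chlorophenyl to 4-methylphenyl: with the rest of the molecule held the same, the step is small (a number 0.3 percentage points lower from compound 2 to compound 3 (within the scatter)). Going by these compounds alone, it also gives the first reading at a second place, the amide-type nitrogen in a ring, where methyl in place of hydrogen leaves the values within the scatter (a number 9.5 percentage points lower from compound 1 to compound 3 (within the scatter)). Neither change is therefore shown to matter at the one dose given, and no measurement at hand bears on why.

From the compounds shown here alone, it remains open whether an amine or a methoxy group on the aromatic carbon would move the read-out beyond the scatter. The same question stands for a longer chain, such as benzyl, on the ring nitrogen.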